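The source may report more compounds than this note shows. Statements on the series, on what has been measured and on what is new or still open speak of the compounds shown alone.

Compound 3 `COc1ccc(NC(=O)C2CCc3ccccc3N2)cc1` stands at the weak end of what has been measured in a functional assay on NCI-H23 cells (Homo sapiens) for cytotoxicity, read by sulforhodamine B assay, with a stated time of 72 h; on this read-out lower numbers stand for stronger inhibition of growth and higher numbers for weaker inhibition of growth: in this assay compound 3 gives 55700 nM, the highest number of the three. Compound 1 `O=C(Nc1ccccc1C(F)(F)F)C1CCc2ccccc2N1C(=O)c1cccc(Cl)c1` gives 292 nM, a far lower number, and compound 2 `CCCCCCCCC(=O)N1c2ccccc2CCC1C(=O)Nc1ccccc1C(F)(F)F` gives 4220 nM, which lies between them. For the measured compounds named here, the only step so far that changes one place at a time is a 14-fold higher number from compound 1 to compound 2 (1.16 log units; beyond the scatter), and it sits on the carbonyl carbon attached to the ring nitrogen of the shared core, a part of the molecule that compound 3 lacks altogether.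

Compound 4 `O=C(Nc1ccccc1)C1CCc2ccccc2N1` differs from compound 3 in a different place: hydrogen in place of methoxy on an aromatic carbon. Going by the values given here, no measured pair shows what removing a methoxy from this aromatic ring does, so the step from compound 1 to compound 2 bears on it only loosely, as a reminder that changes elsewhere can be large. With nothing directly comparable, the change is expected to fall within the scatter, so the estimated step is a 1.1-fold higher number from compound 3 to compound 4 (0.03 log units; within the scatter). Compound 4 is therefore estimated at 60000 nM in this assay, with a plausible range from 20000 nM to 180000 nM.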

Compound 4, concentration for 50% growth inhibition: 97100 nM
For compound 4 the middle estimate is 1.6-fold (0.21 log units) below the measured one; the measured number falls inside the stated range.
By their numbers in this assay, from the lowest: compound 1; then compound 2; then compounds 3 and 4 (each within the scatter of the next).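

In this assay the exchange of methoxy for hydrogen gives a 1.7-fold higher number from compound 3 to compound 4 (0.24 log units; within the scatter) and so stays within the usual scatter of repeated measurements. For the compounds shown here, this is the first look at the aromatic ring of the amide, where the group stands para to a large group, and the pair gives no sign that the methoxy on this aromatic carbon changes the read-out, whereas the only earlier step, a 14-fold higher number from compound 1 to compound 2 (1.16 log units; beyond the scatter) on the carbonyl carbon attached to the ring nitrogen, lies beyond the scatter. No supporting measurement bears on why the pair behaves this way.

A single pair on a core without any group on the ring nitrogen leaves open whether this position would stay as unresponsive with other groups, such as a hydroxy, an amine, a carboxylic acid or a longer alkoxy chain in place of the methoxy. It also leaves open whether the same exchange of methoxy for hydrogen would stay within the scatter on a compound that carries a carbonyl group on the ring nitrogen, as compound 1 and compound 2 do.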